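The source may report more compounds than this note shows. Statements on the series, on what has been measured and on what is new or still open speak of the compounds shown alone.

Series notes. Compound 3 `O=S(=O)(NCCCNCC1COc2ccccc2O1)c1cc(C(F)(F)F)cc(C(F)(F)F)c1` gives 2800 nM in a functional assay on BE(2)-C cells (Homo sapiens) for inhibition, read by MTT assay, with a stated time of 72 h; a higher number here means a weaker inhibitor of growth, a lower number a stronger inhibitor of growth. Compound 1 `O=S(=O)(NCCCNCc1cccc2ccccc12)c1cc(C(F)(F)F)cc(C(F)(F)F)c1` gives 2700 nM in this assay, and compound 2 `COc1cccc(CNCCCNS(=O)(=O)c2cc(C(F)(F)F)cc(C(F)(F)F)c2)c1` gives 4500 nM; all three numbers lie within the scatter of one another, so compound 3 holds no separable place among them. The step from compound 3 to compound 4 `O=S(=O)(NCCCNCc1ccc(Cl)c(C(F)(F)F)c1)c1cc(C(F)(F)F)cc(C(F)(F)F)c1` is 4-chloro-3-(trifluoromethyl)phenyl in place of 2,3-dihydro-1,4-benzodioxin-2-yl on a saturated chain carbon bound to an amine nitrogen. The measured steps at this same place, a 1.7-fold higher number from compound 1 to compound 2 (0.22 log units; within the scatter), a 1.0-fold higher number from compound 1 to compound 3 (0.02 log units; within the scatter) and a 1.6-fold lower number from compound 2 to compound 3 (0.21 log units; within the scatter), all fall within the scatter, so three different groups on the saturated chain carbon bound to the amine nitrogen have left the number in this assay within the scatter. The expectation for compound 4 is therefore no step beyond the scatter, no change at the digits printed from compound 3 to compound 4 (within the scatter). Compound 4 is estimated at 2800 nM, with a range from 1200 nM to 6500 nM.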

Compound 4, concentration for 50% growth inhibition: 8600 nM
Compound 4: middle estimate off by 3.1-fold (0.49 log units), on the low side; measured number above the stated range.
By their numbers in this assay, from the lowest: compounds 1, 3, 2 and 4 (each within the scatter of the next, the first and the last beyond it).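

Within the data shown here, at the saturated chain carbon bound to an amine nitrogen, the group now matters in this assay: 4-chloro-3-(trifluoromethyl)phenyl gives the first steps at this place beyond the scatter, both modest, with a 3.1-fold higher number from compound 3 to compound 4 (0.49 log units; beyond the scatter) and a 3.2-fold higher number from compound 1 to compound 4 (0.50 log units; beyond the scatter). Against 3-methoxyphenyl the same change stays unresolved, with a 1.9-fold higher number from compound 2 to compound 4 (0.28 log units; within the scatter). Nothing available here bears on what lies behind these steps.

From the compounds shown here alone, the chlorine and the trifluoromethyl enter together, so which of them goes with the step remains open; a phenyl carrying only chlorine or only trifluoromethyl would separate them. Also open, going by these compounds, is how a saturated cyclohexyl group would read at this place.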